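A few compounds are considered here, and "the series" means these few. Any claim that something is new, unique, unknown or untested is made for them only; others in the source may bear on it.

Working notes on the series. In an ADME assay on microsomes from liver (Rattus norvegicus) for metabolic stability, with a stated time of 10 min (on this read-out higher numbers stand for a more stable compound and lower numbers for a less stable compound), compound 1 (`COc1ccc2oc(-c3cn4nc(OC)sc4n3)cc2c1`) gives 38%. Compound 3 (`COc1nn2cc(-c3cc4c(OC)ccc(OC)c4o3)nc2s1`) gives 28%, within the scatter of compound 1. Compound 2 (`COc1cc(OCc2cccc(COc3ccccc3)c2)c2cc(-c3cn4nc(OC)sc4n3)oc2c1`) gives 64%, beyond the scatter on the high side of both. Compound 4 (`COc1nn2cc(-c3cc4ccccc4o3)nc2s1`) is still unmeasured and has hydrogen in place of methoxy on an aromatic carbon of compound 1: hydrogen in place of methoxy on an aromatic carbon. Within the data shown here, no measured pair isolates this change, so its size in this assay remains uncertain. The estimated step of a number 2 percentage points higher from compound 1 to compound 4 (within the scatter) is expected to stay within the scatter, with no firm direction. For compound 4 the estimate is 40%, with an expected range of 22% to 58%.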

Compound 4, percent of the compound remaining: 31%
Beside the measured number, compound 4's estimate is 9 percentage points above it; low and high end bracket the measured number.
By their numbers in this assay, from the lowest: compounds 3, 4 and 1 (each within the scatter of the next); then compound 2.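

Hydrogen in place of methoxy on an aromatic carbon of the six-membered aromatic ring now has a measured pair in this assay: a number 7 percentage points lower from compound 1 to compound 4 (within the scatter). On this read-out, this single exchange at this position therefore does not separate the two compounds. Nothing available bears on what lies behind the size of this step. From the compounds shown here alone, it remains open whether an amine, a carboxylic acid or a longer chain at this same position would give a step beyond the scatter. A single pair also leaves open whether this exchange would behave alike on another core.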